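Changing the acid group of compound 2

This account rests on a few compounds, and the source may have more. Where it says the series, first, only, none or still open, it means among the compounds named here.

In a functional assay on K562 cells (Homo sapiens) for cytotoxicity, read by trypan blue exclusion, with a stated time of 96 h (on this read-out higher numbers stand for weaker inhibition and lower numbers for stronger inhibition), compound 1 (`COC(=O)C(Nc1cc(CS(=O)(=O)/C=C/c2c(OC)cc(OC)cc2OC)ccc1OC)c1ccccc1`) gives 30 nM and compound 2 (`COc1cc(OC)c(/C=C/S(=O)(=O)Cc2ccc(OC)c(NC(C)(C)C(=O)O)c2)c(OC)c1`) gives 7.5 nM as the lower of the two numbers. Compound 3 (`COc1ccc(C(Nc2cc(CS(=O)(=O)/C=C/c3c(OC)cc(OC)cc3OC)ccc2OC)C(=O)O)cc1`) has carboxy(4-methoxyphenyl)methyl in place of 1-carboxy-1-methylethyl on a nitrogen on an aromatic ring. The entering group keeps the carboxy of compound 2 and, like the group in compound 1, holds an aromatic ring. Within the data shown here, only one measured step bears on this change, and it swapped 1-carboxy-1-methylethyl for the group in compound 1 at the same place (a 4.0-fold lower number from compound 1 to compound 2 (0.60 log units; beyond the scatter)). That modest step is thin evidence, so only part of it is expected to return, as a higher number. An estimated 2.0-fold higher number from compound 2 to compound 3 (0.30 log units; within the scatter) is therefore what is expected. For compound 3 the expected value is 15 nM (5 nM to 50 nM).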

Compound 3, half-maximal inhibitory concentration: 15 nM
The estimate for compound 3 equals the measured number at the digits printed; measured number inside the range.
By their numbers in this assay, from the lowest: compounds 2, 3 and 1 (each within the scatter of the next, the first and the last beyond it).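

At this nitrogen on the aromatic ring, going from 1-carboxy-1-methylethyl, with 6 heavy atoms and no ring, to carboxy(4-methoxyphenyl)methyl, with 12 heavy atoms and one six-membered aromatic ring, leaves this assay within the usual scatter (a 2.0-fold higher number from compound 2 to compound 3 (0.30 log units; within the scatter)). The step to compound 3 from the ester-bearing compound also stays within the scatter (a 2.0-fold lower number from compound 1 to compound 3 (0.30 log units; within the scatter)), so compound 3 cannot be separated from either neighbour, even though compound 1 and compound 2 lie beyond the scatter of each other. No measurement shown here offers an explanation for these numbers.

On these data alone, what a primary amide in place of the carboxy would give at this nitrogen stays open. So does the reading for carboxy(phenyl)methyl, the same entering group with a plain phenyl ring and no methoxy.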